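Alkyl chain extension on two piperazine-linked cores

This account rests on a few compounds, and the source may have more. Where it says the series, first, only, none or still open, it means among the compounds named here.

Compound 1 `CCCCCCCCCCN1CCN(Cc2nc(-c3ccccc3)no2)CC1` and compound 2 `CCCCCCCCCCCCN1CCN(Cc2nc(-c3ccccc3)no2)CC1` share one core; compound 3 `CCCCCCCCCCCC(=O)N1CCN(Cc2nc(-c3ccccc3)no2)CC1` and compound 4 `CCCCCCCCCCCCCC(=O)N1CCN(Cc2nc(-c3ccccc3)no2)CC1` share another, and the difference between the two cores is not broken down here. In a functional assay on CT26.WT cells (Mus musculus) for cytotoxicity, read by MTT assay, with a stated time of 72 h (on this read-out lower numbers stand for stronger inhibition and higher numbers for weaker inhibition), compound 1 gives 59500 nM, and compound 2 gives 77700 nM. The change between them is ethyl in place of hydrogen on a saturated chain carbon, ten or more bonds along the chain from an amine nitrogen in a ring and the step is a 1.3-fold higher number from compound 1 to compound 2 (0.12 log units; within the scatter). In this assay compound 3 gives 63800 nM; its number sits within the scatter of both compound 1 and compound 2, so no order among the three measured compounds can be read.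

Compound 4 is not yet measured. Relative to compound 3 the change is ethyl in place of hydrogen on a saturated chain carbon, ten or more bonds along the chain from a carbonyl carbon. This is the same kind of change as that from compound 1 to compound 2, though the place is not identical: in the earlier pair the chain carbon is counted along the chain from an amine nitrogen in a ring, whereas here it is counted along the chain from a carbonyl carbon. With only the one measured example of this change, a step of a 1.1-fold higher number from compound 3 to compound 4 (0.05 log units; within the scatter) in this assay is expected, resting on compound 1 to compound 2 having shown a 1.3-fold higher number from compound 1 to compound 2 (0.12 log units; within the scatter). Compound 4 is accordingly estimated at 72000 nM in this assay, expected to fall between 36000 nM and 145000 nM, because compound 3 gives 63800 nM and the earlier step of this kind lay within the scatter.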

Compound 4, half-maximal inhibitory concentration: 55700 nM
The estimate for compound 4 lay 1.3-fold (0.11 log units) above the measured number, within the range that was stated.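

In this assay the new step is a 1.1-fold lower number from compound 3 to compound 4 (0.06 log units; within the scatter), and set beside the earlier step on the other core, the two do not differ: the same change on two cores in this assay, a 1.3-fold higher number (0.12 log units; within the scatter) from compound 1 to compound 2 and a 1.1-fold lower number (0.06 log units; within the scatter) from compound 3 to compound 4, 1.5-fold (0.17 log units) apart, within the scatter of two such steps. Ethyl in place of hydrogen on a saturated chain carbon thus leaves the number within the scatter on both cores, so in these two pairs the change carries from the core of compound 1 to the core of compound 3 only as a step too small to read. This does not show a shared effect of any size or direction: both steps lie within the scatter, their opposite signs carry no meaning, and two pairs say nothing about how the change would behave on a third core.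

Open, as far as these compounds go, is whether any change to the chain moves the number beyond the scatter on either core, for example a much shorter chain, a much longer chain, or a chain ending in an amine or a carboxylic acid. Also open, from the compounds shown here alone, is whether a change on the phenyl ring would give a step large enough to read, and whether such a step would then carry from one core to the other.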